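The compounds below may be only part of what the source reports. "The series", "measured", "known", "first", "only" and "open" are said of these compounds alone.

Compound 1 `C[C@@H](Nc1c(C(=O)NCc2ccc(F)cc2)nc(Br)c2cccnc12)c1ccccc1` was tested in a functional assay on MDA-MB-435 cells (Homo sapiens) for cytotoxicity, read by MTT assay, with a stated time of 72 h (on this read-out higher numbers stand for weaker inhibition and lower numbers for stronger inhibition), and gave only a limit, > 20000 nM, so its value there is not a number. Compound 2 `CN(C)c1ccc(CNC(=O)c2nc(Br)c3cccnc3c2N[C@H]2CC[C@H](N)CC2)cc1` gives 4000 nM in this assay. Compound 1 sits at the limit of > 20000 nM in this assay, at which 1 of the 2 values shown sits. Compound 3 `O=C(NCc1ccc(F)cc1)c1nc(Br)c2cccnc2c1N1CCNCC1` differs from compound 1 in one place: piperazin-1-yl in place of (1-phenylethyl)amino on an aromatic carbon. Among the compounds with values here, no measured step joins the two, so only an expectation can be offered. Compound 3 is expected to reach roughly 8000 nM in this assay, between 2500 nM and 30000 nM, which would mean an estimated gain beyond the scatter an at least 2.5-fold lower number from compound 1 to compound 3 (0.39 log units; beyond the scatter).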

Compound 3, half-maximal inhibitory concentration: 8000 nM
The estimate for compound 3 equals the measured number at the digits printed; the range from low to high includes it.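

On the aromatic carbon para to the bromo group, piperazin-1-yl in place of (1-phenylethyl)amino gives an at least 2.5-fold lower number from compound 1 to compound 3 (0.39 log units; beyond the scatter) in this assay. This shows that the core of compound 3 reaches a measured value there without the six-membered aromatic ring of carbon only. The full size of the step stays unknown, as compound 1 gives only a limit and not a number: the limit of > 20000 nM in this assay, at which 1 of the 3 values shown sits.

The compounds shown leave open which part of the change matters. They also do not show whether morpholine or an open-chain amine on this carbon would behave like piperazin-1-yl.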